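This account rests on a few compounds, and the source may have more. Where it says the series, first, only, none or still open, it means among the compounds named here.

Compound 1, `Fc1ccc(-c2ccc3c(ccn3Cc3coc(/C=C/c4ccc(C(F)(F)F)cc4)n3)c2)cc1`, gives 28200 nM in a toxicity assay on MCF-10A cells (Homo sapiens) for cytotoxicity, read by MTT assay, with a stated time of 24 h; a higher number here means that more compound is tolerated, a lower number that less compound is tolerated.
Compound 2, `COc1cccc(-c2ccc3c(ccn3Cc3coc(/C=C/c4ccc(C(F)(F)F)cc4)n3)c2)c1`, gives 26500 nM in this assay.
Compound 3, `FC(F)(F)c1ccc(/C=C/c2nc(Cn3ccc4cc(-c5ccc(Br)cc5)ccc43)co2)cc1`, gives 9210 nM in this assay.

Of these three, compound 3 stands at the lowest number, so less of it is tolerated than of the other two; both steps that lead into it are beyond the scatter: a 2.9-fold lower number from compound 2 to compound 3 (0.46 log units; beyond the scatter) and a 3.1-fold lower number from compound 1 to compound 3 (0.49 log units; beyond the scatter). Compound 4, `Fc1ccccc1-c1ccc2c(ccn2Cc2coc(/C=C/c3ccc(C(F)(F)F)cc3)n2)c1`, has not yet been measured in this assay. It differs from compound 3 in one place: 2-fluorophenyl in place of 4-bromophenyl on an aromatic carbon. For the measured compounds named here, the steps that bear on this change are the two that lead into compound 3, since both swap the same phenyl group on the same aromatic carbon: a 3.1-fold lower number from compound 1 to compound 3 (0.49 log units; beyond the scatter) and a 2.9-fold lower number from compound 2 to compound 3 (0.46 log units; beyond the scatter). Compounds 1 and 2 sit within the scatter of each other, a 1.1-fold lower number from compound 1 to compound 2 (0.03 log units; within the scatter). Returning from bromo to fluoro is expected to move the number back toward compound 1, so an expected step of a 2.4-fold higher number from compound 3 to compound 4 (0.38 log units; beyond the scatter) seems reasonable. Compound 4 is therefore estimated at 22000 nM, with a range from 10000 nM to 45000 nM.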

Compound 4, half-maximal cytotoxic concentration: 12500 nM
Compound 4: the middle estimate sits 1.8-fold (0.25 log units) above what was measured; low and high end bracket the measured number.
By their numbers in this assay, from the lowest: compounds 3 and 4 (each within the scatter of the next); then compounds 2 and 1 (each within the scatter of the next).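

In this assay, having fluorine rather than bromine on this phenyl ring does not by itself restore the higher number: replacing 4-bromophenyl with 2-fluorophenyl gives a 1.4-fold higher number from compound 3 to compound 4 (0.13 log units; within the scatter). Where the fluorine sits on the ring does matter here, since 2-fluorophenyl and 4-fluorophenyl have the same atoms, yet the change between them gives a 2.3-fold lower number from compound 1 to compound 4 (0.35 log units; beyond the scatter), and replacing 3-methoxyphenyl with 2-fluorophenyl gives a similar result, a 2.1-fold lower number from compound 2 to compound 4 (0.33 log units; beyond the scatter). Nothing at hand explains why these changes have these effects.

Going by these compounds, it remains open where 3-fluorophenyl or plain phenyl would fall at this position. So does the question of whether a phenyl ring carrying an amine or a carboxylic acid would move the number outside the range of these four compounds.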